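The compounds below may be only part of what the source reports. "The series", "measured", "known", "first", "only" and "open" are said of these compounds alone.

Working notes on the series. Among the compounds with values here, compound 1, `Cc1ccc(NS(=O)(=O)C2CCCCC2=O)c(C)c1`, stands higher of the two compounds measured so far: in a functional assay on KB cells (Homo sapiens) for antiproliferative activity, read by sulforhodamine B assay, tested at 100 ug/mL (a higher number here means more inhibition at the concentration tested (going by the name of the read-out), a lower number less inhibition), compound 1 gives 7.97%. Its nearest neighbour is compound 2, `Cc1cc(F)ccc1NS(=O)(=O)C1CCCCC1=O`, which in this assay gives -3.72%. That step is a number 11.7 percentage points lower from compound 1 to compound 2 (beyond the scatter), for fluoro in place of methyl on an aromatic carbon. Compound 3, `Cc1ccc(NS(=O)(=O)C2CCCCC2=O)cc1`, differs from compound 1 by hydrogen in place of methyl on an aromatic carbon, the change sitting on an aromatic carbon of a six-membered aromatic ring of carbon only, ortho to a large group and meta to a methyl group. Within the data shown here, no measured step removes a methyl outright; the one step at hand replaces the same methyl with fluoro and ran modestly downward, so a step of similar or smaller size, downward or within the scatter, is expected here. Compound 3 is therefore estimated at 2%, between -10% and 14%. The expected step is a number 6 percentage points lower from compound 1 to compound 3 (within the scatter).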

Compound 3, a percentage reported as inhibition, at one concentration (the size of the read-out at that concentration, not a potency): -22.2%
Compound 3: the middle estimate sits 24.2 percentage points above what was measured; measured number below the stated range.
By their numbers in this assay, from the lowest: compound 3; then compound 2; then compound 1.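

In this assay, the step is a number 30.2 percentage points lower from compound 1 to compound 3 (beyond the scatter), so the methyl ortho to a large group matters to the read-out and is not a position where hydrogen serves equally well. With fluoro at this same position compound 2 gives -3.72%, with hydrogen compound 3 gives -22.2%, and of the three groups only the methyl, in compound 1, gives a positive number. No measurement at hand bears on what lies behind this step.

The compounds shown leave open whether an ethyl, a methoxy or a chloro at this position would raise the number beyond that of compound 1. They also leave open how the methyl meta to this position, common to compounds 1 and 3, contributes.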